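A few compounds are considered here, and "the series" means these few. Any claim that something is new, unique, unknown or untested is made for them only; others in the source may bear on it.

Working notes on the series. The read-out throughout is a functional assay on the whole organism with Mus musculus as the target; on this read-out lower numbers stand for an effect already at smaller amounts and higher numbers for an effect only at larger amounts of compound. Compound 1 `CCN(C)C(=O)/C=C1\CCc2c(F)cc(F)cc21` gives 56 mg/kg in this assay. Compound 2 `Cc1cccc2c1CC/C2=C\C(=O)NC1CC1` gives 40 mg/kg in this assay. Compound 3 `CCCNC(=O)/C=C1\CCc2ccc(F)cc21` reaches only a limit of the assay, > 100 mg/kg, and the limit of > 100 mg/kg in this assay, at which 1 of the 3 values shown sits, marks where it sits. The two values that are numbers, those of compound 1 and compound 2, lie within the usual scatter of each other and cannot be told apart. Among the measured compounds shown here, no pair among the measured compounds differs in a single place, so no step between them is computed.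

Compound 4 `CNC(=O)/C=C1\CCc2c(F)cc(F)cc21` is not yet measured. It differs from compound 1 in one place: hydrogen in place of ethyl on an amide-type nitrogen. The hydrogen enters on the amide-type nitrogen whose other neighbours are the carbonyl carbon and a saturated chain carbon, so the ethyl(methyl)carbamoyl of compound 1 becomes a methylcarbamoyl.

For the measured compounds named here, nothing among the measured compounds isolates this change. Compound 2 carries a hydrogen on its amide-type nitrogen and has a number in hand, whereas compound 3, also with a hydrogen there, reports a limit; neither shares the core of compound 1. The step is expected to be small, a 1.1-fold higher number from compound 1 to compound 4 (0.03 log units; within the scatter), with no clear direction beyond the scatter. Compound 4 is estimated at 60 mg/kg, with a range from 25 mg/kg to 150 mg/kg in this assay.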

Compound 4, dose for half-maximal effect: 45 mg/kg
For compound 4 the middle estimate is 1.3-fold (0.12 log units) above the measured one; the measured number falls inside the stated range.
By their numbers in this assay, from the lowest: compounds 2, 4 and 1 (each within the scatter of the next). At a limit, above all of these: compound 3.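

Among the compounds shown here, on the core of compound 1, hydrogen in place of ethyl on an amide-type nitrogen gives, in this assay, a 1.2-fold lower number from compound 1 to compound 4 (0.09 log units; within the scatter), and this is the first single-place step. At this position the ethyl group can therefore be lost without a change that can be told from the scatter: the ethyl(methyl)carbamoyl and the methylcarbamoyl cannot be separated on this read-out, and the amide hydrogen that enters brings no measurable penalty or gain. The measurements shown give no cause for this step.

Going by these compounds, what happens with a longer chain such as butyl, a benzyl group, or a chain carrying an amine on the same nitrogen stays open, as does the effect of a carboxylic acid in place of the amide. Also open is what the fluoro groups on the core of compound 1 contribute, as no single-place step among the compounds shown touches them.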